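Swapping a dichlorobenzyl for a methoxybenzyl on the shared core

The source may report more compounds than this note shows. Statements on the series, on what has been measured and on what is new or still open speak of the compounds shown alone.

Of the compounds shown here, three on one shared core have been measured in a functional assay on CAKI-1 cells (Homo sapiens) for inhibition, read by sulforhodamine B assay, with a stated time of 48 h; on this read-out lower numbers stand for stronger inhibition of growth and higher numbers for weaker inhibition of growth. Compound 1, `Nc1cc(N)c2nc(-c3ccccc3)c(NCc3ccc(Cl)c(Cl)c3)nc2c1`, gives 52500 nM in this assay, the highest of the two numbers reported. Compound 3, `Nc1cc(N)c2nc(-c3ccccc3)c(Oc3ccc(F)cc3)nc2c1`, gives 24500 nM in this assay, a value that lies beyond the usual scatter from that of compound 1. Compound 2, `CCOC(=O)[C@H](CCC(=O)O)NC(=O)c1ccc(Sc2nc3cc(N)cc(N)c3nc2-c2ccccc2)cc1`, gives only a limit of the assay, < 100000 nM, and not a number. That reading is the limit of < 100000 nM in this assay, at which 1 of the 3 values shown sits.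

Compound 4, `COc1ccc(CNc2nc3cc(N)cc(N)c3nc2-c2ccccc2)cc1`, has not yet been measured in this assay. It differs from compound 1 in one place: 4-methoxyphenyl in place of 3,4-dichlorophenyl on a saturated chain carbon bound to a nitrogen on an aromatic ring. Among the measured compounds shown here, no measured pair shows the effect of this change on the shared core, so there is no direct guide to the size of the step.

With only the numbers of compound 1 and compound 3 to lean on, compound 4 is expected to stay close to compound 1, with a step from compound 1 to compound 4 of about a 1.0-fold higher number from compound 1 to compound 4 (0.02 log units; within the scatter) in this assay, in either direction within the usual scatter. The estimate for compound 4 in this assay is therefore 55000 nM, most likely between 20000 nM and 100000 nM.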

Compound 4, concentration for total growth inhibition: 36300 nM
Compound 4: middle estimate off by 1.5-fold (0.18 log units), on the high side; the range from low to high includes it.
By their numbers in this assay, from the lowest: compounds 3, 4 and 1 (each within the scatter of the next, the first and the last beyond it).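

Measured in this assay, the swap of 3,4-dichlorophenyl for 4-methoxyphenyl on a saturated chain carbon bound to a nitrogen on an aromatic ring gives a 1.4-fold lower number from compound 1 to compound 4 (0.16 log units; within the scatter), so the two numbers cannot be told apart. Among the compounds shown here, this is the first step read at this position, and it shows that the read-out here does not separate the two groups, even though both chlorine atoms leave, an oxygen enters, and the group goes from 0 hydrogen-bond acceptors to 1 at the same 8 heavy atoms. Nothing measured here bears on why these two groups read alike.

This one pair exchanges both substituents on the phenyl ring at once, so it cannot show what a single chlorine or a methoxy group does alone. On these data alone, whether a carboxylic acid or an amine on that phenyl ring, or a longer chain carrying the ring in place of the benzyl carbon, would move the number beyond the usual scatter remains open.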